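The compounds below may be only part of what the source reports. "The series", "measured", "known", "first", "only" and "open" are said of these compounds alone.

In an ADME assay on HepG2 cells (Homo sapiens) for cytotoxicity, read by MTT assay, with a stated time of 72 h (on this read-out lower numbers stand for higher toxicity in this test and higher numbers for lower toxicity in this test), compound 1 (`COc1ccccc1C#Cc1cc(Cl)cn2c([N+](=O)[O-])c(CS(=O)(=O)c3ccccc3)nc12`) gives > 3900 nM as a limit of the assay, not a number. Compound 2 (`O=[N+]([O-])c1c(CS(=O)(=O)c2ccccc2)nc2c(C#Cc3cccs3)cc(Cl)cn12`) gives > 3900 nM as a limit too, so it holds no numeric place in the series. Compound 3 (`O=[N+]([O-])c1c(CS(=O)(=O)c2ccccc2)nc2c(C#Cc3cccnc3)cc(Cl)cn12`) differs from compound 2 by pyridin-3-yl in place of thiophen-2-yl on a triple-bonded carbon with pyridin-3-yl in place of thiophen-2-yl on a triple-bonded carbon. Going by the values given here, the one measured step (a step that the two limits leave unreadable from compound 1 to compound 2) has no readable size, and the limit of > 3900 nM in this assay, at which 2 of the 2 values shown sit, is all the numbers show, so no step beyond the scatter is expected in either direction. The expected step (a step that the limit leaves unreadable from compound 2 to compound 3) is an estimate only. For compound 3 the estimated value is 5500 nM with an expected range from 2500 nM to 20000 nM and another limit is likely.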

Compound 3, half-maximal cytotoxic concentration: > 3900 nM
Compound 3 was reported as a limit; the forecaster's own chance of this, stated with the estimate: 75%; the middle value does not contradict the limit.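

In this assay, going by these compounds alone, compound 3 gives > 3900 nM, a limit and not a number, and no new step from compound 1 or compound 2 to compound 3 can be read. The compounds shown leave open where the actual cytotoxic concentrations of compound 1, compound 2 and compound 3 lie, and whether the group on the triple-bonded carbon changes them.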